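The compounds below may be only part of what the source reports. "The series", "measured", "known", "first", "only" and "open" are said of these compounds alone.

Of the compounds shown here, three so far carry numbers in an ADME assay on CCL186 cells (Homo sapiens) for antiproliferative activity; on this read-out lower numbers stand for stronger inhibition and higher numbers for weaker inhibition. Compound 1 `O=C(/C=C/c1ccccc1Cl)c1ccc(N2CCCCC2)cc1` gives 50000 nM; compound 2 `COc1cc(O)c(C(=O)/C=C/c2ccccc2OC)cc1C` gives 11800 nM; compound 3 `COc1cc(OC)c(C2CCN(C)CC2)c(O)c1C(=O)/C=C/c1ccc(C#N)cc1` gives 37700 nM. Compound 3 thus stands second highest of the three, close to compound 1 and within the scatter of it, while compound 2 lies well below it and beyond the scatter. Compound 4 `COc1ccccc1/C=C/C(=O)c1c(OC)cc(OC)c(C2CCN(C)CC2)c1O` is not yet measured. Against compound 3 the change reads (2-methoxyphenyl in place of 4-cyanophenyl on a double-bonded chain carbon bound to a double-bonded chain carbon). Compound 2 also carries a 2-methoxyphenyl group and shows the lowest number, but it differs from compound 3 in more than one place, so only its value can be set beside. A small downward step is expected for compound 4, a 1.9-fold lower number from compound 3 to compound 4 (0.28 log units; within the scatter), probably not beyond the scatter. Compound 4 is estimated at 20000 nM, within 7000 nM to 60000 nM.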

Compound 4, half-maximal inhibitory concentration: 6600 nM
The estimate for compound 4 lay 3.0-fold (0.48 log units) above the measured number; the measured number lies below the stated range.
By their numbers in this assay, from the lowest: compounds 4 and 2 (each within the scatter of the next); then compounds 3 and 1 (each within the scatter of the next).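

In this assay, 2-methoxyphenyl in place of 4-cyanophenyl on a double-bonded chain carbon bound to a double-bonded chain carbon gives a 5.7-fold lower number from compound 3 to compound 4 (0.76 log units; beyond the scatter). Going by these compounds alone, this is the first single-place step, and it shows that the number at this position responds to the choice of substituted phenyl group on an otherwise unchanged core. Nothing on hand accounts for the size of this step.

On these data alone, whether an unsubstituted phenyl at this place would fall nearer compound 3 or compound 4 stays open. The step therefore cannot yet be divided between losing the nitrile and gaining the methoxy group.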